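A few compounds are considered here, and "the series" means these few. Any claim that something is new, unique, unknown or untested is made for them only; others in the source may bear on it.

Measured so far in an ADME assay on Vero cells (Chlorocebus sabaeus) for cytotoxicity, read by MTT assay, with a stated time of 72 h; a higher number here means that more compound is tolerated, a lower number that less compound is tolerated:

Compound 1, `CNC1=C([N+](=O)[O-])C(c2ccc(N3CCN(c4ccnc5cc(Cl)ccc45)CC3)cc2)c2ccccc2O1` — compound 1 gives > 200000 nM, a limit of the assay.
Compound 2, `CNC1=C([N+](=O)[O-])C(c2ccc(N3CCN(c4ccnc5cc(Cl)ccc45)CC3)cc2)c2cc(Br)cc(Br)c2O1` — compound 2 gives > 200000 nM, also a limit of the assay.
Compound 3, `O=[N+]([O-])C1=C(NCc2ccccc2)Oc2ccccc2C1c1ccc(N2CCN(c3ccnc4cc(Cl)ccc34)CC2)cc1` — compound 3 gives 66500 nM.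

Among the compounds with values here, compound 3 thus carries the only number in this assay; the other two values are limits, and the limit of > 200000 nM in this assay, at which 2 of the 3 values shown sit, is the only other evidence on the measured steps. Within the data shown here, the one step that can be read is an at least 3.0-fold lower number from compound 1 to compound 3 (0.47 log units; beyond the scatter), where the phenyl on the saturated chain carbon bound to the amine nitrogen went along with a lower tolerated concentration.

Compound 4, `CCCCNC1=C([N+](=O)[O-])C(c2ccc(N3CCN(c4ccnc5cc(Cl)ccc45)CC3)cc2)c2ccccc2O1`, differs from compound 3 in one place: propyl in place of phenyl on a saturated chain carbon bound to an amine nitrogen, so the benzylamino becomes a butylamino. That change removes the same phenyl that the measured step introduced, replacing it with a propyl rather than with hydrogen. The measured step from compound 1 to compound 3 therefore bears on it, in the opposite direction, and an at least modest rise in the tolerated concentration is expected, a 2.1-fold higher number from compound 3 to compound 4 (0.32 log units; beyond the scatter), possibly reaching the limit again. Compound 4 is expected to give about 140000 nM, with a range from 60000 nM to 250000 nM.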

Compound 4, half-maximal cytotoxic concentration: 107000 nM
Compound 4: middle estimate off by 1.3-fold (0.12 log units), on the high side; measured number inside the range.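

In this assay, within the data shown here, propyl in place of phenyl gives a 1.6-fold higher number from compound 3 to compound 4 (0.21 log units; within the scatter), so on this saturated chain carbon bound to an amine nitrogen the two groups cannot be told apart, which the earlier compounds could not show. As far as this pair goes, the six-membered aromatic ring is not required for a number in this range. Propyl in place of hydrogen gives an at least 1.8-fold lower number from compound 1 to compound 4 (0.27 log units; that floor lies within the scatter), so the propyl cannot yet be said to lower the number as the phenyl did.

As far as these compounds go, the full size of the steps that start from compound 1 stays unknown, since its value is only a limit: the limit of > 200000 nM in this assay, at which 2 of the 4 values shown sit. From the compounds shown here alone, whether a longer chain, or a chain ending in an amine or a carboxylic acid, at this place would keep the number in this range remains open.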